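The source may report more compounds than this note shows. Statements on the series, on what has been measured and on what is new or still open speak of the compounds shown alone.

Compound 1 `COC(=O)[C@@H](NC(=O)c1ccc(NC(=O)C(=O)c2ccccc2NC(C)=O)cc1)C(C)C` gave 2.8 nM in an assay on mitochondria from liver for inhibition of Amine oxidase [flavin-containing] A (Rattus norvegicus), with a stated time of 60 min; on this read-out higher numbers stand for weaker inhibition and lower numbers for stronger inhibition.
Compound 2 `COC(=O)C[C@H](NC(=O)c1ccc(NC(=O)C(=O)c2ccccc2NC(C)=O)cc1)C(=O)OC` gave 60 nM in this assay.

For the measured compounds named here, of these two numbers, compound 2 holds the higher one, so it is the weaker inhibitor of the pair; the only neighbour, compound 1, sits a 21-fold higher number from compound 1 to compound 2 (1.33 log units; beyond the scatter) away in the opposite direction. Compound 3 `COC(=O)CCCCCNC(=O)c1ccc(NC(=O)C(=O)c2ccccc2NC(C)=O)cc1` has not yet been measured. It differs from compound 2 in one place: 5-(methoxycarbonyl)pentyl in place of 1,2-bis(methoxycarbonyl)ethyl on an amide-type nitrogen. The side chain on the amide-type nitrogen thus loses both of its ester groups and its stereocentre and becomes a longer, unbranched chain that ends in a single ester.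

Going by the values given here, only one measured step speaks to this region of the molecule: a 21-fold higher number from compound 1 to compound 2 (1.33 log units; beyond the scatter), which shows that the group on this nitrogen can shift the number strongly. That step, however, compared two branched groups, neither of which resembles the new chain, so it gives the size of the effect this position can have but not its direction here. A step toward a lower number is thought plausible for compound 3, though a change within the scatter cannot be ruled out. Compound 3 is expected to come in near 30 nM, within 8 nM to 120 nM, which would mean a step of a 2.0-fold lower number from compound 2 to compound 3 (0.30 log units; within the scatter) from compound 2 to compound 3.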

Compound 3, half-maximal inhibitory concentration: 930000 nM
The estimate for compound 3 lay 31000-fold (4.49 log units) below the measured number; measured number outside the range, above it.
By their numbers in this assay, from the lowest: compound 1; then compound 2; then compound 3.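

In this assay, 5-(methoxycarbonyl)pentyl in place of 1,2-bis(methoxycarbonyl)ethyl on the amide-type nitrogen gives a 16000-fold higher number from compound 2 to compound 3 (4.19 log units; beyond the scatter), far larger than the earlier 21-fold higher number from compound 1 to compound 2 (1.33 log units; beyond the scatter). Set against the other branched group, 1-(methoxycarbonyl)-2-methylpropyl, the same unbranched chain gives a 330000-fold higher number from compound 1 to compound 3 (5.52 log units; beyond the scatter), so the two branched groups differ from each other much less than either differs from this chain, and inhibition at this position is not kept merely by having a chain that ends in a methyl ester. No measurement at hand accounts for this loss.

Compound 3 changes several things at once, since it loses the branch and the stereocentre, gains chain length and keeps a single ester, so the compounds shown cannot tell which of these changes carries the step. A shorter unbranched chain ending in the same methyl ester, or a carboxylic acid in place of that ester, would be needed to begin separating these changes.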